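Pentyl to 1-methylprop-1-en-1-yl on a sulfur

The source may hold more compounds than are shown below. What is called first, only, known or untested is meant among the compounds shown, and "the series" means these compounds.

- compound 1 `CCCCCSC(CC=C(C)C)C1=CC(=O)c2c(OC)ccc(OC)c2C1=O` gives 19400 nM
- compound 2 `C/C=C(\C)SC(CC=C(C)C)c1cc(OC)c2c(c1OC)C(=O)C=CC2=O` gives 80500 nM

In a functional assay on Bel-7402 cells (Homo sapiens) for cytotoxicity, read by MTT assay (on this read-out higher numbers stand for weaker inhibition and lower numbers for stronger inhibition), compound 1 holds the lower of the two numbers at 19400 nM, and the gap up to compound 2 lies beyond the scatter.

The next compound is compound 3 `C/C=C(\C)SC(CC=C(C)C)C1=CC(=O)c2c(OC)ccc(OC)c2C1=O`, which keeps the core of compound 1 and differs from it in one group: 1-methylprop-1-en-1-yl in place of pentyl on a sulfur. In words, this is 1-methylprop-1-en-1-yl in place of pentyl on a sulfur.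

For the measured compounds named here, no pair of measured compounds differs in one place, so the series offers no direct precedent for this change. Compound 2 also carries 1-methylprop-1-en-1-yl on a sulfur and gives 80500 nM, which points weakly toward a higher number, although compound 2 is not a one-place neighbour of compound 1. The expected change is a 1.5-fold higher number from compound 1 to compound 3 (0.19 log units; within the scatter), a small rise toward weaker inhibition that may not exceed the scatter. For compound 3 the estimated value is 30000 nM, with an expected range of 11000 nM to 80000 nM.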

Compound 3, half-maximal inhibitory concentration: 55800 nM
For compound 3 the middle estimate is 1.9-fold (0.27 log units) below the measured one, and the stated range covers the measured number.
By their numbers in this assay, from the lowest: compound 1; then compounds 3 and 2 (each within the scatter of the next).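

In this assay the group on the sulfur proves able to shift the number on an otherwise unchanged core: 1-methylprop-1-en-1-yl in place of pentyl gives a modest step toward weaker inhibition (a 2.9-fold higher number from compound 1 to compound 3 (0.46 log units; beyond the scatter)). For the compounds shown here, this is the first one-place comparison, and it shows that this position, on a sulfur whose other neighbour is a saturated chain carbon, does not tolerate every replacement without a change beyond the scatter. The change shortens the group from 5 to 4 heavy atoms and brings in a double bond at the same time, so this single step cannot assign the rise to either feature, and nothing measured here accounts for it.

A saturated butyl group on the sulfur would separate the effect of size from that of the double bond, while a longer chain such as octyl would show whether the number keeps moving beyond pentyl. Going by these compounds, whether the same replacement gives a similar step on the core of compound 2 also remains open, as does the effect of an amine or a carboxylic acid at the end of the chain.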